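This account rests on a few compounds, and the source may have more. Where it says the series, first, only, none or still open, it means among the compounds named here.

Compound 1 `CCCc1nnc(SC)n2c(CCC)nc(C)c12` was tested in a functional assay for inhibition, with Homo sapiens as the target; a higher number here means a weaker inhibitor, a lower number a stronger inhibitor. In this assay compound 1 gives > 48000 nM, which is a limit of the measurement rather than a number. Compound 2 `CCCc1nc(C)c2cnn(CC(O)CO)c(=O)n12` was tested in the same way. In this assay compound 2 gives > 48000 nM, again a limit and not a number. Compound 1 therefore stands at the limit of > 48000 nM in this assay, at which 2 of the 2 values shown sit, so only a bound, and no measured strength, is known for it. Among the measured compounds shown here, no step between two measured compounds is available. Compound 3 `CCCc1nc(C)c2c(C)nnc(SC)n12` is not yet measured. It differs from compound 1 by hydrogen in place of ethyl on a saturated chain carbon bound to an aromatic carbon. The step in this assay is expected to be none beyond the usual scatter, so an estimated step that the limit leaves unreadable from compound 1 to compound 3 is anticipated, because compound 1 sits at the limit of > 48000 nM in this assay, at which 2 of the 2 values shown sit. Compound 3 is estimated to give 80000 nM in this assay, with a range from 20000 nM to 300000 nM, most likely reported once more only as a limit.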

Compound 3, half-maximal inhibitory concentration: > 48000 nM
Compound 3 was reported as a limit; the forecaster's own chance of this, stated with the estimate: 85%; the middle value lies beyond the limit too.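

Among the compounds shown here, compound 1 and compound 3 both give only a limit in this assay, so no step between them can be read: the limit of > 48000 nM in this assay, at which 3 of the 3 values shown sit. The compounds shown leave open how strongly any of them inhibits, and whether hydrogen in place of ethyl changes that at all.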